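Swapping the halogenated ring on the carbonyl of compound 2

This account rests on a few compounds, and the source may have more. Where it says the series, first, only, none or still open, it means among the compounds named here.

Compound 1 `COc1cc(OC)c(C(=O)c2cccc(Cl)c2)c(O)c1CN1CCCC1` and compound 2 `COc1cc(OC)c(C(=O)c2cccc(Cl)c2)c(O)c1CN1CCCCC1` share one core and differ only in the ring bound to a saturated chain carbon. In a functional assay on THP-1 cells (Homo sapiens) for inhibition, read by ELISA, with stated times of 30 min and 24 h, tested at 1 uM (a higher number here means a stronger effect of the compound at the concentration tested, a lower number a weaker effect), compound 1 gives 41%, and compound 2 gives 33%. The step of a number 8 percentage points lower from compound 1 to compound 2 (within the scatter) keeps the two within the scatter, so compound 2 holds the lowest of the two numbers only nominally, and no order between them can be claimed. Compound 3 `COc1cc(OC)c(C(=O)c2ccccc2F)c(O)c1CN1CCCCC1` keeps the piperidin-1-yl ring of compound 2 and alters a different place: 2-fluorophenyl in place of 3-chlorophenyl on a carbonyl carbon. Going by the values given here, no measured step touches this carbonyl-bound ring, since the single step from compound 1 to compound 2 concerns the pyrrolidin-1-yl to piperidin-1-yl exchange, so the data offer no direction. The expected step of no change at the digits printed from compound 2 to compound 3 (within the scatter) is therefore none beyond the scatter, with a wide range. In this assay compound 3 is estimated at 33%, between 12% and 55%.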

Compound 3, a percentage reported as activity, at one concentration (the size of the read-out at that concentration, not a potency): 18%
Beside the measured number, compound 3's estimate is 15 percentage points above it; low and high end bracket the measured number.
By their numbers in this assay, from the lowest: compound 3; then compounds 2 and 1 (each within the scatter of the next).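

In this assay, going by these compounds alone, the ring on the carbonyl carbon is the first place where a single change moves the number beyond the scatter: 2-fluorophenyl in place of 3-chlorophenyl gives a number 15 percentage points lower from compound 2 to compound 3 (beyond the scatter). The exchange of the saturated ring, by contrast, stayed within the scatter, with a number 8 percentage points lower from compound 1 to compound 2 (within the scatter). Nothing shown gives a measured reason for the drop at the carbonyl-bound ring.

This change swaps the halogen and alters its place on the ring at once, so these compounds cannot separate the two contributions. On these data alone, a plain phenyl ring or a methoxyphenyl ring on the carbonyl would help show how much the halogen matters, and whether 2-fluorophenyl behaves the same way with pyrrolidin-1-yl also remains open.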